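This account rests on a few compounds, and the source may have more. Where it says the series, first, only, none or still open, it means among the compounds named here.

Measured:
compound 1 `COc1nc(C)c(CCF)c(OC)n1` — in a functional assay on HCT-116 cells (Homo sapiens) for antiproliferative activity, read by MTT assay, with a stated time of 24 h (on this read-out lower numbers stand for stronger inhibition and higher numbers for weaker inhibition), compound 1 gives > 100000 nM, a limit of the assay.
compound 2 `COc1nc(Cl)nc(C)c1CCF` — in this assay compound 2 gives > 100000 nM, again a limit of the assay.

Compound 1 therefore stands only at a limit, and the step from compound 1 to compound 2 a step that the two limits leave unreadable from compound 1 to compound 2 cannot be sized; both values sit at the same limit (the limit of > 100000 nM in this assay, at which 2 of the 2 values shown sit).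

Compound 3 `COc1nc(C)c(CCCl)c(OC)n1` differs from compound 1 by chloro in place of fluoro on a saturated chain carbon, two bonds along the chain from an aromatic carbon. Among the measured compounds shown here, the one measured step concerns a different place on the shared core and, being unreadable, gives no direction or size to carry over. For the measured compounds named here, no measured pair shows what this exchange does in this assay, so the expectation rests on where compound 1 stands: a value at or near the same limit, with no step beyond the scatter expected from compound 1 to compound 3 a number no higher from compound 1 to compound 3 (the limit leaves the size open). For compound 3 the estimate is 100000 nM, in the range 30000 nM to 300000 nM.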

Compound 3, half-maximal inhibitory concentration: > 100000 nM
Compound 3: only a limit was reported (the forecaster's own chance of this, stated with the estimate: 85%); the middle value lies on the limit itself.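

In this assay compound 3 gives > 100000 nM, a limit of the assay. No step can be read from compound 1 to compound 3: the limit of > 100000 nM in this assay, at which 3 of the 3 values shown sit. The compounds shown leave open whether 2-fluoroethyl to 2-chloroethyl changes antiproliferative activity at all, and which change on the shared core would give a value inside the measurable range.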